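This account rests on a few compounds, and the source may have more. Where it says the series, first, only, none or still open, it means among the compounds named here.

In a functional assay on U-373MG ATCC cells (Homo sapiens) for antiproliferative activity, read by MTT assay, with a stated time of 3 days (a lower number here means a stronger inhibitor, a higher number a weaker inhibitor), compound 1 `CC(C)CN1C(=O)C=C(Cl)C1(O)c1ccccc1` gives 765 nM. Its closest measured relative, compound 2 `CC(C)CN1C(=O)C=C(Cl)C1(O)c1ccc(Cl)cc1`, gives 475 nM, so the two cannot be told apart: the step is a 1.6-fold lower number from compound 1 to compound 2 (0.21 log units; within the scatter). Compound 3 `O=C1C=C(Cl)C(O)(c2ccccc2)N1Cc1ccccc1` keeps the core of compound 1 but swaps one group: phenyl in place of isopropyl on a saturated chain carbon bound to an amide-type nitrogen in a ring. Put simply, isobutyl becomes benzyl. For the measured compounds named here, the only measured step involves a different change, chloro in place of hydrogen on an aromatic carbon, so it offers weak guidance, and no shift beyond the scatter is expected. For compound 3 the estimated value is 600 nM, with an expected range of 200 nM to 1800 nM. The expected step is a 1.3-fold lower number from compound 1 to compound 3 (0.11 log units; within the scatter).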

Compound 3, half-maximal inhibitory concentration: 23 nM
The estimate for compound 3 lay 26-fold (1.42 log units) above the measured number; measured number below the stated range.
By their numbers in this assay, from the lowest: compound 3; then compounds 2 and 1 (each within the scatter of the next).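

In this assay the change from isobutyl to benzyl gives a 33-fold lower number from compound 1 to compound 3 (1.52 log units; beyond the scatter), so the group at this position can move the number far beyond the scatter, which the earlier step, made elsewhere on the molecule, did not show. Here phenyl in place of isopropyl on a saturated chain carbon bound to an amide-type nitrogen in a ring is a large gain. No measurement shown explains this gain. Still open, as far as these compounds go, is whether an aromatic ring is needed at all, or whether a cyclohexyl group would do as well. A longer chain carrying the phenyl also remains untested among the compounds shown.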